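Methyl for Methoxy: Expectation Without a Measured Step

The source may hold more compounds than are shown below. What is called first, only, known or untested is meant among the compounds shown, and "the series" means these compounds.

compound 1, `CC(C)(C)OC(=O)N1CCN(C(=S)SCc2cn(-c3ccccc3F)nn2)CC1` — > 128000 nM
compound 2, `COc1ccc(Cn2cc(CSC(=S)N3CCN(C(=O)OCc4ccccc4)CC3)nn2)cc1` — 58300 nM

In a functional assay on ECa-109 cells (Homo sapiens) for inhibition, read by MTT assay, with a stated time of 72 h (a higher number here means a weaker inhibitor, a lower number a stronger inhibitor), compound 1 reaches only a limit, > 128000 nM. Going by the values given here, compound 2 is the one compound with a number in this assay, where it gives 58300 nM; the other value present is the limit of > 128000 nM in this assay, at which 1 of the 2 values shown sits. Among the compounds with values here, no pair of measured compounds differing in one place exists here, so no measured step is available.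

Compound 3, `Cc1ccc(Cn2cc(CSC(=S)N3CCN(C(=O)OCc4ccccc4)CC3)nn2)cc1`, is the unmeasured neighbour of compound 2. The change is methyl in place of methoxy on an aromatic carbon. Within the data shown here, with no measured step to lean on, the expected change in this assay from compound 2 to compound 3 is none beyond the scatter, with a somewhat wider range because a limit is possible. The expected step is a 1.1-fold higher number from compound 2 to compound 3 (0.05 log units; within the scatter). Compound 3 is estimated at 65000 nM, within 25000 nM to 160000 nM.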

Compound 3, half-maximal inhibitory concentration: 32600 nM
For compound 3 the middle estimate is 2.0-fold (0.30 log units) above the measured one; low and high end bracket the measured number.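

In this assay, going by these compounds alone, the change of 4-methoxybenzyl to 4-methylbenzyl gives a 1.8-fold lower number from compound 2 to compound 3 (0.25 log units; within the scatter) and is the first measured step in this set. The position therefore keeps its read-out when the methoxy, with its hydrogen-bond acceptor, gives way to a methyl that has none, and the two compounds cannot be placed in any order. Nothing shown gives a cause for this step or bears on it.

The compounds shown leave open whether a different group at this place, such as an amine, a carboxylic acid or a trifluoromethyl group, would move the number beyond the scatter. They also leave open whether the same exchange of methoxy for methyl would read alike in another cell line.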